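A Sulfur Substituent Exchange and Growth Inhibition

The compounds below may be only part of what the source reports. "The series", "measured", "known", "first", "only" and "open" are said of these compounds alone.

Among the measured compounds shown here, in a functional assay on DU-145 cells (Homo sapiens) for inhibition, read by trypan blue exclusion, with a stated time of 96 h (on this read-out higher numbers stand for weaker inhibition of growth and lower numbers for stronger inhibition of growth), compound 1 (`O=C(/C(=C\c1ccc(O)cc1O)Sc1ccc(Br)cc1)c1ccc(Cl)cc1`) gives 50000 nM, the only actual number available so far. Compound 2 (`O=C(/C(=C\c1c(O)cc(O)cc1O)SCc1ccc(Cl)cc1)c1ccc(Cl)cc1`) returns only a limit, > 100000 nM, and no number. Compound 2 therefore stands at the limit of > 100000 nM in this assay, at which 1 of the 2 values shown sits.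

Compound 3 (`O=C(/C(=C\c1c(O)cc(O)cc1O)Sc1ccc(Br)cc1)c1ccc(Cl)cc1`) has 4-bromophenyl in place of 4-chlorobenzyl on a sulfur. For the measured compounds named here, no measured pair shows this exchange on its own, so any forecast rests on thin ground. Going by the values given here, a modest move toward stronger inhibition of growth in this assay is expected, with compound 1 at 50000 nM as the sole numerical guide. The expected change is an at least 2.5-fold lower number from compound 2 to compound 3 (0.39 log units; beyond the scatter). Compound 3 is estimated at 40000 nM, with an expected range of 12000 nM to 100000 nM.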

Compound 3, concentration for 50% growth inhibition: 50000 nM
Beside the measured number, compound 3's estimate is 1.3-fold (0.10 log units) below it, within the range that was stated.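

With 4-bromophenyl in place of 4-chlorobenzyl on a sulfur, this assay gives an at least 2.0-fold lower number from compound 2 to compound 3 (0.30 log units; that floor lies within the scatter), the first step read at this position, and its floor alone does not separate the two compounds. Compound 2 carries a limit and not a number: the limit of > 100000 nM in this assay, at which 1 of the 3 values shown sits. The second new comparison, hydroxy in place of hydrogen on an aromatic carbon, gives no change at the digits printed from compound 1 to compound 3 (within the scatter), so with 4-bromophenyl on the sulfur this hydroxy leaves the read-out unmoved.

The exchange on the sulfur alters both the halogen and the carbon count, and the compounds shown do not separate these two parts or fix the full size of the step. From the compounds shown here alone, how a carboxylic acid or a longer chain on the sulfur would read in this assay also remains open.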